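Replacing Phenoxy in Compound 2

This account rests on a few compounds, and the source may have more. Where it says the series, first, only, none or still open, it means among the compounds named here.

Going by the values given here, only one compound offers any guidance on how compound 3 might behave, and that guidance is thin. In a functional assay on MGC-803 cells (Homo sapiens) for antiproliferative activity, read by CCK-8 assay, with a stated time of 72 h (on this read-out lower numbers stand for stronger inhibition and higher numbers for weaker inhibition), compound 1 `O=C(/C=C/c1ccc(CN2CCc3ccccc32)cc1)NO` gives "not determined" (no result reported), so it adds no number to work from. Compound 2 `Nc1ccccc1NC(=O)/C=C/c1ccc(COc2ccccc2)cc1` gives > 32000 nM in this assay, which is a limit of the assay and not a number. Compound 2 therefore has no exact position on the scale.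

Compound 3 `Nc1ccccc1NC(=O)/C=C/c1ccc(CN2CCc3ccccc32)cc1` comes from compound 2 through one structural change: 2,3-dihydro-1H-indol-1-yl in place of phenoxy on a saturated chain carbon bound to an aromatic carbon. The rest of the structure stays the same. Among the compounds with values here, no pair of measured compounds shows what a swap of this kind does in this assay, so any forecast here is loose and its range has to be wide.

A modest move toward stronger inhibition is expected, estimated as an at least 2.6-fold lower number from compound 2 to compound 3 (0.42 log units; beyond the scatter). For compound 3 the expected value is 12000 nM, with an estimated range of 2500 nM to 40000 nM.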

Compound 3, half-maximal inhibitory concentration: > 32000 nM
Compound 3: no number, only a limit (the forecaster's own chance of this, stated with the estimate: 35%); middle value at least 2.6-fold (0.42 log units) away from the limit.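

No step from compound 2 to compound 3 can be read, since each gives only a limit of the assay and not a number: the limit of > 32000 nM in this assay, at which 2 of the 3 values shown sit.

The compounds shown leave open how strong the antiproliferative activity of either compound is, and whether 2,3-dihydro-1H-indol-1-yl in place of phenoxy changes it at all.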